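The source may report more compounds than this note shows. Statements on the series, on what has been measured and on what is new or still open speak of the compounds shown alone.

Measured compounds: compound 1 `COc1ccc2cc(-c3cccc(-c4cccnc4)c3)ccc2c1` and compound 2 `Oc1ccc2cc(-c3cccc(-c4cccnc4)c3)ccc2c1`.

In an assay for inhibition of steroid 17-alpha-hydroxylase/17,20 lyase (Homo sapiens), tested at 2 uM (on this read-out lower numbers stand for a weaker effect and higher numbers for a stronger effect at the one concentration tested), compound 1 gives 4%, the lowest of the two numbers shown. Compound 2 gives 8%; the step of a number 4 percentage points higher from compound 1 to compound 2 (within the scatter) is within the scatter, so the two stand level. Compound 3 `COc1ccc2cc(-c3cccc(Cn4ccnc4)c3)ccc2c1` is not yet measured. It differs from compound 1 by (1H-imidazol-1-yl)methyl in place of pyridin-3-yl on an aromatic carbon. For the measured compounds named here, no measured step bears on this change: the single step between compound 1 and compound 2 concerns hydrogen in place of methyl on an oxygen on an aromatic ring, not the group that changes here, and it was within the scatter. The expectation for compound 3 therefore rests on compound 1 alone, with a wide range. A modest rise is expected, a number 21 percentage points higher from compound 1 to compound 3 (beyond the scatter), but a value near compound 1 cannot be excluded. Compound 3 is estimated at 25%, within 2% to 65%.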

Compound 3, a percentage reported as inhibition, at one concentration (the size of the read-out at that concentration, not a potency): 28%
Compound 3: middle estimate off by 3 percentage points, on the low side; measured number inside the range.
By their numbers in this assay, from the lowest: compounds 1 and 2 (each within the scatter of the next); then compound 3.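

In this assay, this aromatic carbon, meta to a large group, proves responsive to the group it carries: placing (1H-imidazol-1-yl)methyl there in place of pyridin-3-yl gives a number 24 percentage points higher from compound 1 to compound 3 (beyond the scatter). For the compounds shown here, the only earlier step, a number 4 percentage points higher from compound 1 to compound 2 (within the scatter), concerned the methyl on the oxygen and showed no change beyond the scatter, so this is the first clear difference, although the read-out remains modest at the one concentration tested. The heavy-atom count stays the same across the change, while a six-membered aromatic ring gives way to a five-membered one with two hetero atoms; no measurement given here accounts for the rise.

The compounds shown leave open whether the rise follows the imidazole ring or its methylene link, which a directly attached imidazol-1-yl or a pyridin-3-ylmethyl group would separate. They also leave open how a simple amine would read at this position.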